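Hydroxamate series: removing the phenyl from the chain carbon

The source may report more compounds than this note shows. Statements on the series, on what has been measured and on what is new or still open speak of the compounds shown alone.

Measured so far:
compound 1 `O=C(NO)c1ccc(CNC(c2ccccc2)c2nnnn2C2CCCCC2)cc1` — 120 nM
compound 2 `O=C(NO)c1ccc(CNC(c2ccccc2)c2nnnn2Cc2ccccc2)cc1` — 100 nM

Both compounds were read in an assay on isolated protein for inhibition of protein deacetylase HDAC6 (Homo sapiens), read by fluorescence, with a stated time of 90 min; a lower number here means a stronger inhibitor, a higher number a weaker inhibitor. Among the two numbers so far, compound 1 gives the higher one; its nearest neighbour is compound 2, and the step of a 1.2-fold lower number from compound 1 to compound 2 (0.08 log units; within the scatter) lies within the scatter, so the two cannot be ordered. That single step concerns the group on the aromatic nitrogen only.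

Compound 3 `O=C(NO)c1ccc(CNCc2nnnn2C2CCCCC2)cc1` has not been measured. It differs from compound 1 in one place: hydrogen in place of phenyl on a saturated chain carbon bound to an amine nitrogen and an aromatic carbon. Going by the values given here, no measured step touches the chain carbon bound to the amine nitrogen and the aromatic carbon, so nothing in the data bears directly on this change. Among the compounds with values here, the only step available, from compound 1 to compound 2, is small and elsewhere in the molecule; it gives no guide to size or direction here. Removing a whole ring is a larger change than any yet tried, and the estimate for compound 3 is therefore kept wide. Compound 3 is expected to give 300 nM, with a range from 100 nM to 900 nM. This corresponds to an expected step of a 2.5-fold higher number from compound 1 to compound 3 (0.40 log units; beyond the scatter).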

Compound 3, half-maximal inhibitory concentration: 120 nM
Compound 3: middle estimate off by 2.5-fold (0.40 log units), on the high side; the range from low to high includes it.
By their numbers in this assay, from the lowest: compounds 2, 1 and 3 (each within the scatter of the next).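

In this assay, going by these compounds alone, hydrogen in place of phenyl on a saturated chain carbon bound to an amine nitrogen and an aromatic carbon gives no change at the digits printed from compound 1 to compound 3 (within the scatter) and so provides the first measured step at this position, which the earlier pair did not touch. With cyclohexyl on the aromatic nitrogen, the loss of the whole phenyl, with its 6 heavy atoms, leaves the number within the scatter, so this ring is not required to keep the value of compound 1 in this assay. No available measurement offers an explanation for this outcome.

Whether the same replacement holds with benzyl on the aromatic nitrogen, as in compound 2, remains open, since the compounds shown test it only with cyclohexyl. Also open, from the compounds shown here alone, is how this chain carbon responds to groups other than phenyl and hydrogen, such as a methyl, a carboxylic acid or an amine, and whether any of these would move the number beyond the scatter.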